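Swapping Trifluoromethoxy for Nitro on the Amide Ring

The source may report more compounds than this note shows. Statements on the series, on what has been measured and on what is new or still open speak of the compounds shown alone.

Three amides share one core. Compound 1 `O=C(Nc1cc(-c2ccccc2)nn1-c1ccccc1)c1cccc([N+](=O)[O-])c1` and compound 2 `O=C(Nc1cc(-c2ccccc2)nn1-c1ccccc1)c1ccc(OC(F)(F)F)cc1` have been tested in an assay on HEK293 cells for displacement of a labelled ligand from metabotropic glutamate receptor 5 (Rattus norvegicus); on this read-out higher numbers stand for weaker inhibition and lower numbers for stronger inhibition: compound 1 gives 2220 nM and compound 2 gives 265 nM, the lowest of the two numbers, with compound 1 sitting well beyond the scatter above it. Compound 3 `O=C(Nc1cc(-c2ccccc2)nn1-c1ccccc1)c1ccc([N+](=O)[O-])cc1` is not yet measured. It differs from compound 2 by nitro in place of trifluoromethoxy on an aromatic carbon. Going by the values given here, no measured pair shows this exact change, so its size is uncertain. A step toward weaker inhibition beyond the scatter is expected, a 3.8-fold higher number from compound 2 to compound 3 (0.58 log units; beyond the scatter). For compound 3 the estimated value in this assay is 1000 nM, between 300 nM and 4000 nM.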

Compound 3, inhibition constant: 250 nM
Beside the measured number, compound 3's estimate is 4.0-fold (0.60 log units) above it; the whole stated range lies above it.
By their numbers in this assay, from the lowest: compounds 3 and 2 (each within the scatter of the next); then compound 1.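

Where the group sits para to a large group, nitro and trifluoromethoxy cannot be told apart: the swap gives a 1.1-fold lower number from compound 2 to compound 3 (0.03 log units; within the scatter). The place of the nitro group matters far more, since 4-nitrophenyl in place of 3-nitrophenyl gives an 8.9-fold lower number from compound 1 to compound 3 (0.95 log units; beyond the scatter). Nothing measured here gives a reason for either step.

From the compounds shown here alone, it remains open whether an amine, a carboxylic acid or a longer chain at this same place would keep the number close to that of compound 2. Also open, going by these compounds, is whether trifluoromethoxy responds to that change of place as nitro does.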